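From 3-methoxyphenyl to 4-methoxyphenyl in a cell toxicity test

The compounds below may be only part of what the source reports. "The series", "measured", "known", "first", "only" and "open" are said of these compounds alone.

Measured so far in a toxicity assay on HaCaT cells (Homo sapiens) for cytotoxicity, read by CCK-8 assay, with a stated time of 24 h (on this read-out lower numbers stand for higher toxicity in this test and higher numbers for lower toxicity in this test), are these two:
- compound 1 `COc1ccccc1Oc1c(N)nc(-c2ccc(C)cc2)nc1Cl` with 6300 nM as its value
- compound 2 `COc1cccc(-c2nc(N)c(Oc3ccccc3OC)c(Cl)n2)c1` with 14000 nM as its value

Compound 2 holds the higher of the two numbers with 14000 nM as its value, and a higher number means lower toxicity here. The next compound, compound 3 `COc1ccc(-c2nc(N)c(Oc3ccccc3OC)c(Cl)n2)cc1`, keeps the shared core and differs in one group: 4-methoxyphenyl in place of 3-methoxyphenyl on an aromatic carbon. In short, 4-methoxyphenyl comes in place of 3-methoxyphenyl on an aromatic carbon between two ring nitrogen atoms.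

Among the measured compounds shown here, only one measured step bears on this: a 2.2-fold higher number from compound 1 to compound 2 (0.35 log units; beyond the scatter). That step is modest, and it swaps 4-methylphenyl for 3-methoxyphenyl at the same place, so it is a loose guide. For the measured compounds named here, no measured pair shows the new change alone. Compound 1, which carries 4-methylphenyl, has the lower number at 6300 nM and suggests a slight lean downward. In this assay the expected change is a 1.4-fold lower number from compound 2 to compound 3 (0.15 log units; within the scatter), probably nothing beyond the scatter. For compound 3 the expected value is 10000 nM, with an estimated range from 4500 nM to 22000 nM.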

Compound 3, half-maximal cytotoxic concentration: 8200 nM
For compound 3 the middle estimate is 1.2-fold (0.09 log units) above the measured one; the range from low to high includes it.
By their numbers in this assay, from the lowest: compounds 1, 3 and 2 (each within the scatter of the next, the first and the last beyond it).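

In this assay, swapping 3-methoxyphenyl for 4-methoxyphenyl on the aromatic carbon between two ring nitrogen atoms gives a 1.7-fold lower number from compound 2 to compound 3 (0.23 log units; within the scatter), so with the same atoms joined differently, this change cannot be told apart from repeat-to-repeat variation. Compound 3 also links the earlier pair. Among the compounds shown here, it differs from compound 1 only in methoxy for methyl, and that change gives a 1.3-fold higher number from compound 1 to compound 3 (0.11 log units; within the scatter); the step beyond the scatter, a 2.2-fold higher number from compound 1 to compound 2 (0.35 log units; beyond the scatter), therefore breaks into two single changes that each stay within it, although this rests on only three compounds. No experimental information here explains the small differences among these compounds.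

These three compounds cover only closely related substituted phenyl groups at this place, so they leave open whether a much different group, such as a phenyl ring carrying an amine or a carboxylic acid, would move the number well beyond the scatter. They also cannot show whether the same small differences would appear with the other parts of the shared core changed, or in a different test.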